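Second chloro group on a chlorophenyl imine

The source may hold more compounds than are shown below. What is called first, only, known or untested is meant among the compounds shown, and "the series" means these compounds.

Three compounds have been measured in a functional assay on HUVEC cells (Homo sapiens) for antiproliferative activity; on this read-out lower numbers stand for stronger inhibition and higher numbers for weaker inhibition:
compound 1 `Cc1nc2c([nH]1)C(=O)/C(=N/c1cccc(Cl)c1)C(Cl)=C2O` gives 600 nM
compound 2 `Cc1nc2c([nH]1)C(=O)/C(=N/c1ccc(Cl)cc1)C(Cl)=C2O` gives 800 nM
compound 3 `Cc1nc2c([nH]1)C(=O)/C(=N/c1ccc(Cl)cc1Cl)C(Cl)=C2O` gives 500 nM

Compounds 1 and 2 share the same atoms joined differently, (3-chlorophenyl in place of 4-chlorophenyl on a double-bonded nitrogen), and their values lie within the scatter, a 1.3-fold higher number from compound 1 to compound 2 (0.12 log units; within the scatter). Compound 4 `Cc1nc2c([nH]1)C(=O)/C(=N/c1cccc(Cl)c1Cl)C(Cl)=C2O` is not yet measured; it differs from compound 1 by chloro in place of hydrogen on an aromatic carbon. The same kind of change was made once before, from compound 2 to compound 3, (chloro in place of hydrogen on an aromatic carbon), and gave a 1.6-fold lower number from compound 2 to compound 3 (0.20 log units; within the scatter). The places are not the same word for word: in compound 4 the entering chloro sits ortho to a chloro group, in compound 3 meta to a chloro group, so it is the same kind of change, not the same. For compound 4 the expected step is a 1.5-fold lower number from compound 1 to compound 4 (0.18 log units; within the scatter), resting on a 1.6-fold lower number from compound 2 to compound 3 (0.20 log units; within the scatter). Compound 4 is therefore estimated at 400 nM.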

Compound 4, half-maximal inhibitory concentration: 300 nM
The estimate for compound 4 lay 1.3-fold (0.12 log units) above the measured number; measured number inside the range.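

In this assay, chloro in place of hydrogen on the aromatic carbon of compound 1 gives a 2.0-fold lower number from compound 1 to compound 4 (0.30 log units; within the scatter). Set beside the earlier case, the two steps do not differ: the same change on two cores in this assay, a 1.6-fold lower number (0.20 log units; within the scatter) from compound 2 to compound 3 and a 2.0-fold lower number (0.30 log units; within the scatter) from compound 1 to compound 4, 1.3-fold (0.10 log units) apart, within the scatter of two such steps. The change therefore carries across these two cores with a similar outcome, but each step lies within the scatter, so this pair does not show that the second chloro group strengthens inhibition on either core, nor does it show how the change would behave on any other core.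

The compounds shown leave open whether a different group at this place, such as a methoxy group, an amine or a carboxylic acid, would give a step beyond the scatter. They also leave open what replacing the methyl group on the shared core would do.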